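A few compounds are considered here, and "the series" means these few. Any claim that something is new, unique, unknown or untested is made for them only; others in the source may bear on it.

The measured compounds in an ADME assay on L929 cells (Mus musculus) for cytotoxicity, read by resazurin assay, with a stated time of 72 h; a higher number here means a weaker inhibitor, a lower number a stronger inhibitor:

Compound 1 `O=C(/C=C/c1ccc2c(c1)B(O)OC2)c1ccccc1` gives > 10 ug/mL, a limit of the assay.
Compound 2 `COc1ccc(C(=O)/C=C/c2ccc3c(c2)B(O)OC3)cc1` gives > 10 ug/mL, a limit of the assay.
Compound 3 `CSc1ccc(C(=O)/C=C/c2ccc3c(c2)B(O)OC3)cc1` gives > 10 ug/mL, a limit of the assay.

Compound 1 stands only at a limit in this assay, and the same holds for both compounds measured beside it, all three sitting at the limit of > 10 ug/mL in this assay, at which 3 of the 3 values shown sit. The steps a step that the two limits leave unreadable from compound 1 to compound 2, a step that the two limits leave unreadable from compound 1 to compound 3 and a step that the two limits leave unreadable from compound 2 to compound 3 are unreadable in size. Compound 4 `O=C(/C=C/c1ccc2c(c1)B(O)OC2)c1cccc(O)c1` differs from compound 1 by hydroxy in place of hydrogen on an aromatic carbon. For the measured compounds named here, no measured step gives a readable size for a change of this kind, so no step beyond the scatter is expected in either direction in this assay. Compound 4 is therefore expected to give 20 ug/mL, ranging from 10 ug/mL to 45 ug/mL. The step expected from this is a step that the limit leaves unreadable from compound 1 to compound 4.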

Compound 4, half-maximal inhibitory concentration: 7.56 ug/mL
Compound 4: middle estimate off by 2.6-fold (0.42 log units), on the high side; measured number outside the range, below it.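

For the compounds shown here, compound 4 is the first compound here to give a number rather than a limit in this assay, which sets it apart from the others: the limit of > 10 ug/mL in this assay, at which 3 of the 4 values shown sit. As far as these compounds go, with hydroxy on the aromatic carbon meta to a large group, the change reads as an at least 1.3-fold lower number from compound 1 to compound 4 (0.12 log units; that floor lies within the scatter), so a lower number is indicated, but its true size is unknown. The steps among compounds 1, 2 and 3 cannot be read. From the compounds shown here alone, whether an amine or a carboxylic acid at this place would also give a readable number remains open, as does the effect of hydroxy on another carbon of this ring.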